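Swapping a Bromophenyl for a Dimethoxyphenyl on a Nucleoside

A few compounds are considered here, and "the series" means these few. Any claim that something is new, unique, unknown or untested is made for them only; others in the source may bear on it.

Three compounds share one sugar-bearing core and differ only in the group carried on a saturated chain carbon bound to a nitrogen on an aromatic ring. In a functional assay on MCF cells (Homo sapiens) for antiproliferative activity, with a stated time of 72 h (a lower number here means a stronger inhibitor, a higher number a weaker inhibitor), compound 1 `OC[C@H]1O[C@@H](n2cnc3c(NCc4ccc(F)cc4)ncnc32)[C@H](O)[C@@H]1O` gives 21000 nM. Compound 2 `OC[C@H]1O[C@@H](n2cnc3c(NCc4ccc(Br)cc4)ncnc32)[C@H](O)[C@@H]1O` reaches only the limit of this assay, > 166000 nM, so no number is known for it. Compound 3 `Cc1cccc(CNc2ncnc3c2ncn3[C@@H]2O[C@H](CO)[C@@H](O)[C@H]2O)c1` likewise sits at a limit, > 166000 nM. The step of an at least 7.9-fold higher number from compound 1 to compound 2 (0.89 log units; beyond the scatter) and the step of an at least 7.9-fold higher number from compound 1 to compound 3 (0.89 log units; beyond the scatter) both move toward weaker inhibition, while the step that the two limits leave unreadable from compound 2 to compound 3 cannot be read because of the limit of > 166000 nM in this assay, at which 2 of the 3 values shown sit. Compound 4 `COc1cc(CNc2ncnc3c2ncn3[C@@H]2O[C@H](CO)[C@@H](O)[C@H]2O)cc(OC)c1` has not yet been measured; it differs from compound 2 in one place: 3,5-dimethoxyphenyl in place of 4-bromophenyl on a saturated chain carbon bound to a nitrogen on an aromatic ring. Within the data shown here, no measured step carries this exact change, and the only measured step that starts from compound 2 is unreadable, so the expectation rests on where compound 2 already stands and on the fact that every change away from the fluoro group of compound 1 has so far weakened inhibition. Compound 4 is expected to remain weak, near the limit, an estimated step of an at least 1.3-fold lower number from compound 2 to compound 4 (0.14 log units; that floor lies within the scatter). The estimated value of compound 4 in this assay is 120000 nM, with a range from 30000 nM to 300000 nM.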

Compound 4, half-maximal inhibitory concentration: > 166000 nM
Compound 4: only a limit was reported (the forecaster's own chance of this, stated with the estimate: 60%); middle value at least 1.3-fold (0.14 log units) from the limit.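

Replacing 4-bromophenyl with 3,5-dimethoxyphenyl, on a saturated chain carbon bound to a nitrogen on an aromatic ring, brings in two oxygen atoms and two hydrogen-bond acceptors, yet the result in this assay still does not move off the limit. Among these compounds, the one readable step is an at least 7.9-fold higher number from compound 1 to compound 4 (0.89 log units; beyond the scatter), so a third group in place of 4-fluorophenyl falls on the weak side, and compound 1 remains the only compound here with an actual number. The steps among compound 2, compound 3 and compound 4 cannot be read, because all three stop at the same limit: the limit of > 166000 nM in this assay, at which 3 of the 4 values shown sit.

How far apart compound 2, compound 3 and compound 4 truly lie stays unknown, as does whether the methoxy groups themselves matter, since the limit hides any difference among these three compounds. Also open, as far as these compounds go, is whether a 4-chlorophenyl group, which stays closer to the 4-fluorophenyl of compound 1, or an amine or a carboxylic acid on the same phenyl ring, would give a measurable value in this assay.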